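The compounds below may be only part of what the source reports. "The series", "measured", "known", "first", "only" and "open" are said of these compounds alone.

In an ADME assay on L929 cells (Mus musculus) for cytotoxicity, read by resazurin assay, with a stated time of 72 h (a lower number here means a stronger inhibitor, a higher number a weaker inhibitor), three compounds built on a shared core have been measured. Compound 1 `CNC(=O)c1cccn1-c1ccc2c(c1)B(O)OC2` gives > 10 ug/mL, which is a limit of the assay rather than a number. Compound 2 `O=C(c1ccc(Cl)cc1)c1ccn(-c2ccc3c(c2)B(O)OC3)c1` likewise gives > 10 ug/mL, again a limit and not a number. Compound 3 `COc1cc(C(=O)c2ccn(-c3ccc4c(c3)B(O)OC4)c2)cc(OC)c1OC` gives 1.15 ug/mL. Compound 2 thus stands at the limit of > 10 ug/mL in this assay, at which 2 of the 3 values shown sit. Among the measured compounds shown here, of the three values shown, only that of compound 3 is an actual number, so the set offers little spread to work from.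

Compound 4 `O=C(CCc1ccccc1)c1ccn(-c2ccc3c(c2)B(O)OC3)c1` has not yet been measured in this assay. It differs from compound 2 in a single place: phenethyl in place of 4-chlorophenyl on a carbonyl carbon. For the measured compounds named here, no step between two measured compounds is available to show what phenethyl in place of 4-chlorophenyl on a carbonyl carbon does here. The expected step of a number no higher from compound 2 to compound 4 (the limit leaves the size open) is therefore one of no clear direction, not beyond the usual scatter. Compound 2 sits at a limit, and compound 4 may well sit there too. Compound 4 is expected to give about 10 ug/mL, with a likely range from 4 ug/mL to 25 ug/mL.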

Compound 4, half-maximal inhibitory concentration: > 10 ug/mL
Compound 4: a limit, no number; the forecaster's own chance of this, stated with the estimate: 60%; the middle value lies on the limit itself.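

Compound 4 gives > 10 ug/mL, which is a limit of the assay and not a number, and compound 2 also sits at a limit, so no step can be read between these two compounds: the limit of > 10 ug/mL in this assay, at which 3 of the 4 values shown sit.

The compounds shown leave open how phenethyl and 4-chlorophenyl on a carbonyl carbon compare in this assay.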